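Compound 3 to compound 4: changing the ring nitrogen group

The compounds below may be only part of what the source reports. "The series", "measured", "known", "first", "only" and "open" are said of these compounds alone.

Values measured so far in a physicochemical assay for solubility, with a stated time of 24 h, tested at 30 mg/mL (a higher number here means a more soluble compound, a lower number a less soluble compound), for the series
- compound 1 `CC(=O)N1CC(CC(=O)NO)(NS(=O)(=O)c2ccc(OCc3cc(C)nc4ccccc34)cc2)C1` gives 800000 nM
- compound 2 `Cc1cc(COc2ccc(S(=O)(=O)NC3(CC(=O)NO)CC3)cc2)c2ccccc2n1` gives 1600000 nM
- compound 3 `CCCCN1CC(CC(=O)NO)(NS(=O)(=O)c2ccc(OCc3cc(C)nc4ccccc34)cc2)C1` gives 4900000 nM

Compound 3 at 4900000 nM stands highest of the three, and its gaps to compound 2 and compound 1 both lie beyond the scatter. Within the data shown here, compound 4 `Cc1cc(COc2ccc(S(=O)(=O)NC3(CC(=O)NO)CN(C(=O)N4CCCCC4)C3)cc2)c2ccccc2n1` has not yet been measured and carries (piperidin-1-yl)carbonyl in place of butyl on an amine nitrogen in a ring as its single change from compound 3.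

Among the measured compounds shown here, one measured step bears on this change, a 6.1-fold higher number from compound 1 to compound 3 (0.79 log units; beyond the scatter) with butyl in place of acetyl on the same nitrogen. Acetyl and (piperidin-1-yl)carbonyl both attach through a carbonyl, so that step, read in reverse, is the closest guide. For the measured compounds named here, the six-membered ring in the entering group has no measured counterpart, which leaves the estimate uncertain. Going by the values given here, compound 2 offers no step at this nitrogen.

A lower number in this assay is therefore expected, of about the same modest size as the step from compound 1. The expected change is a 7.0-fold lower number from compound 3 to compound 4 (0.85 log units; beyond the scatter) in this estimate. For compound 4 the estimated value is 700000 nM with an expected range from 200000 nM to 2500000 nM at this stage.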

Compound 4, solubility: 500000 nM
Compound 4: the middle estimate sits 1.4-fold (0.15 log units) above what was measured; low and high end bracket the measured number.
By their numbers in this assay, from the lowest: compounds 4, 1 and 2 (each within the scatter of the next, the first and the last beyond it); then compound 3.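

In this assay the lower number is no longer tied to acetyl alone, since a second group attached through a carbonyl on the same amine nitrogen in a ring gives a 9.8-fold lower number from compound 3 to compound 4 (0.99 log units; beyond the scatter), so compound 3 with butyl stands beyond the scatter from both carbonyl compounds. Within the carbonyl pair, the size of the group on the carbonyl carbon has no readable effect here, with piperidin-1-yl in place of methyl giving a 1.6-fold lower number from compound 1 to compound 4 (0.20 log units; within the scatter), which leaves compound 1 and compound 4 within the scatter of each other despite the added six-membered ring. No measured evidence is available to explain either step.

With butyl as the only group at this nitrogen that lacks a carbonyl, the compounds shown cannot tell whether the higher number belongs to butyl itself or extends to other groups attached directly through carbon, such as methyl, benzyl or a longer chain. Also open, going by these compounds, is how the unsubstituted ring nitrogen, or a sulfonyl group, a carbamate or a urea with an open-chain amine in place of piperidine, would compare at this position.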